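This account rests on a few compounds, and the source may have more. Where it says the series, first, only, none or still open, it means among the compounds named here.

Working notes on the series. Compound 1 `Cc1cc(=O)n(-c2ccccc2OC(F)(F)F)nc1C(=O)Nc1ccc(Oc2ncnc3ccsc23)cc1` gives 23800 nM in a functional assay on MCF7 cells (Homo sapiens) for cytotoxicity, read by MTT assay, with a stated time of 72 h; on this read-out lower numbers stand for stronger inhibition and higher numbers for weaker inhibition. Compound 2 `Cc1cc(=O)n(-c2cccc(F)c2)nc1C(=O)Nc1ccc(Oc2ncnc3ccsc23)cc1` gives 6410 nM in this assay; the change 3-fluorophenyl in place of 2-(trifluoromethoxy)phenyl on an aromatic nitrogen produced a 3.7-fold lower number from compound 1 to compound 2 (0.57 log units; beyond the scatter). Compound 3 `Cc1cc(=O)n(-c2ccccc2OC(F)(F)F)nc1C(=O)Nc1ccc(Oc2ncnc3ccsc23)c(F)c1` gives 11500 nM in this assay; its core differs from the core of compound 1 by fluoro in place of hydrogen on an aromatic carbon, a step of a 2.1-fold lower number from compound 1 to compound 3 (0.32 log units; beyond the scatter). The values of compound 2 and compound 3 lie within the scatter of each other.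

Compound 4 `Cc1cc(=O)n(-c2cccc(F)c2)nc1C(=O)Nc1ccc(Oc2ncnc3ccsc23)c(F)c1` is not yet measured. For the measured compounds named here, it differs from compound 3 by 3-fluorophenyl in place of 2-(trifluoromethoxy)phenyl on an aromatic nitrogen, the same change, at the same place, as the one that turned compound 1 into compound 2. Going by the values given here, for compound 4 the step is expected to be a 3.6-fold lower number from compound 3 to compound 4 (0.56 log units; beyond the scatter), in size close to the earlier step, because a 3.7-fold lower number from compound 1 to compound 2 (0.57 log units; beyond the scatter) is the only record of this change. Compound 4 is therefore estimated at 3200 nM, between 1400 nM and 7000 nM.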

Compound 4, half-maximal inhibitory concentration: 9050 nM
Compound 4: middle estimate off by 2.8-fold (0.45 log units), on the low side, and the stated range ends below it.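

In this assay, 3-fluorophenyl in place of 2-(trifluoromethoxy)phenyl gives a 1.3-fold lower number from compound 3 to compound 4 (0.10 log units; within the scatter), so the step seen on the core of compound 1 does not carry over in size to the fluorinated core: the same change on two cores in this assay, a 3.7-fold lower number (0.57 log units; beyond the scatter) from compound 1 to compound 2 and a 1.3-fold lower number (0.10 log units; within the scatter) from compound 3 to compound 4, 2.9-fold (0.47 log units) apart, beyond the scatter of two such steps

Fluoro in place of hydrogen on an aromatic carbon gives a 1.4-fold higher number from compound 2 to compound 4 (0.15 log units; within the scatter), so its step also depends on the group on the aromatic nitrogen: the same change on two cores in this assay, a 2.1-fold lower number (0.32 log units; beyond the scatter) from compound 1 to compound 3 and a 1.4-fold higher number (0.15 log units; within the scatter) from compound 2 to compound 4, 2.9-fold (0.47 log units) apart, beyond the scatter of two such steps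

For the compounds shown here, the two changes therefore do not add up across these compounds, but four compounds give only one such comparison and show neither a cause nor a rule for other cores.

From the compounds shown here alone, whether the same holds with an unsubstituted phenyl on the aromatic nitrogen, or with chloro in place of the fluoro on the core, stays open.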